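A few compounds are considered here, and "the series" means these few. Any claim that something is new, unique, unknown or untested is made for them only; others in the source may bear on it.

In a functional assay on MCF7 cells (Homo sapiens) for antiproliferative activity, read by MTT assay, with a stated time of 72 h (a lower number here means a stronger inhibitor, a higher number a weaker inhibitor), compound 1 (`O=c1oc2cc(O)ccc2cc1-c1ccc(O)cc1`) gives > 100000 nM, which is a limit of the assay and not a number. Compound 2 (`Cc1cc(O)ccc1-c1c(C)c2ccc(O)cc2oc1=O`) gives > 100000 nM, again a limit. Going by the values given here, compound 3 (`Cc1c(-c2ccc(O)cc2Cl)c(=O)oc2cc(O)ccc12`) gives 21600 nM, the only true number in this small set. The other readings stand at the limit of > 100000 nM in this assay, at which 2 of the 3 values shown sit.

Compound 4 (`CCc1c(-c2ccc(O)cc2Cl)c(=O)oc2cc(O)ccc12`) comes from compound 3 through a single change, (methyl in place of hydrogen on a saturated chain carbon bound to an aromatic carbon), which can also be read as methyl to ethyl. Among the compounds with values here, the only measured step is an at least 4.6-fold lower number from compound 2 to compound 3 (0.66 log units; beyond the scatter). It is beyond the scatter, but it concerns chloro in place of methyl on an aromatic carbon, not the saturated chain carbon altered here. Within the data shown here, no measured step tests the new change, so that step gives neither a size nor a direction for it.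

With no such guide, the expectation in this assay rests on compound 3 at 21600 nM, and no shift beyond the scatter is expected. The expected change is a 1.1-fold lower number from compound 3 to compound 4 (0.03 log units; within the scatter). For compound 4 the estimated value is 20000 nM, with an expected range of 7000 nM to 60000 nM. A reading that reaches only the limit of the assay remains possible.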

Compound 4, half-maximal inhibitory concentration: 49300 nM
The estimate for compound 4 lay 2.5-fold (0.39 log units) below the measured number; measured number inside the range.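

In this assay, going by these compounds alone, this is the first measured test of the saturated chain carbon bound to an aromatic carbon, and it gives the change both a direction and a size, with a 2.3-fold higher number from compound 3 to compound 4 (0.36 log units; beyond the scatter) for methyl to ethyl. The earlier step concerned chloro in place of methyl on an aromatic carbon and said nothing about this place, whereas here a single added carbon moves the number beyond the scatter, so this place is not indifferent to what stands on it. Compound 4 still gives a true number and not a limit, so this step has a definite size, while the other readings in the set remain at the ceiling of the assay: the limit of > 100000 nM in this assay, at which 2 of the 4 values shown sit.

From the compounds shown here alone, whether a longer chain such as propyl, or an amine or a hydroxyl on this chain carbon, would move the number further in the same direction stays open. A single step also cannot tell whether methyl to ethyl would act in the same way on a compound without the chloro group.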